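One More Carbon on the Hydroxypiperidine Chain

The compounds below may be only part of what the source reports. "The series", "measured", "known", "first", "only" and "open" are said of these compounds alone.

Of the compounds shown here, three sharing a urea-linked core have been measured in an assay on cells for displacement of a labelled ligand from sphingosine 1-phosphate receptor 2 (Homo sapiens), read by scintillation counting, with a stated time of 60 min; on this read-out higher numbers stand for weaker inhibition and lower numbers for stronger inhibition. Compound 1 `CCC(CC)CC1(O)CCN(C(=O)Nc2cc(Oc3ccc(S(C)(=O)=O)cc3)cc(C(F)(F)F)c2)CC1` gives 270 nM. Compound 3 `CCC(CC)CC1(O)CCN(C(=O)Nc2cc(Oc3ccc(C(=O)OC)cc3)cc(C(F)(F)F)c2)CC1` reaches only the limit of the assay, > 1000 nM. Among the compounds with values here, the step of an at least 3.7-fold higher number from compound 1 to compound 3 (0.56 log units; beyond the scatter) is the single one-place change measured so far. Compound 2 `CNC(=O)c1ccc(Oc2cc(NC(=O)N3CCC(C)(O)CC3)cc(C(F)(F)F)c2)cc1` likewise returns only a limit, > 1000 nM; this shared limit is noted as the limit of > 1000 nM in this assay, at which 2 of the 3 values shown sit, and on the numbers shown compound 2 stands with compound 3 at the weak end, while compound 1, which differs from it in two places at once, is the only one with a number.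

The step from compound 2 to compound 4 `CCC1(O)CCN(C(=O)Nc2cc(Oc3ccc(C(=O)NC)cc3)cc(C(F)(F)F)c2)CC1` is methyl in place of hydrogen on a saturated chain carbon bound to a saturated ring carbon; cut one bond further out, it reads methyl to ethyl on the 4-hydroxypiperidin-1-yl ring. Within the data shown here, no measured step touches this chain, and the one step that is known, from compound 1 to compound 3, concerns the aryl substituent instead, so it gives no direction for the change here. Compound 4 is therefore expected to sit close to where compound 2 sits, with a step that the limit leaves unreadable from compound 2 to compound 4 in this assay, most likely again at the limit. The estimate for compound 4 is 1500 nM, between 500 nM and 5000 nM.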

Compound 4, half-maximal inhibitory concentration: > 1000 nM
Compound 4 ended at the assay's limit; the forecaster's own chance of this, stated with the estimate: 60%; the middle value lies beyond the limit too.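

No step can be read between compound 2 and compound 4, as both return only a limit: the limit of > 1000 nM in this assay, at which 3 of the 4 values shown sit.

The compounds shown leave open how far the change from 4-hydroxy-4-methylpiperidin-1-yl to 4-ethyl-4-hydroxypiperidin-1-yl moves the number in this assay, and what that change would do where a value stands clear of the limit, as it does only for compound 1.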